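This account rests on a few compounds, and the source may have more. Where it says the series, first, only, none or still open, it means among the compounds named here.

Measured compounds and their values:
Compound 1 `COc1ccc(-n2ccc(=O)c(C(=O)Nc3ccc(Oc4ccnc5c4ccn5C)c(F)c3)n2)cc1`: in a functional assay on PC-3 cells (Homo sapiens) for cytotoxicity, read by MTT assay, with a stated time of 72 h (a higher number here means a weaker inhibitor, a lower number a stronger inhibitor), compound 1 gives only a limit, > 60000 nM.
Compound 2 `Cn1ccc2c(Oc3ccc(NC(=O)c4nn(-c5ccc(Br)cc5)ccc4=O)cc3F)ccnc21`: in this assay compound 2 gives only a limit, > 60000 nM.
Compound 3 `Cn1ccc2c(Oc3ccc(NC(=O)c4nn(-c5ccccc5)ccc4=O)cc3F)ccnc21`: in this assay compound 3 gives only a limit, > 60000 nM.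

Compound 3 therefore stands at the same limit as the two others; none of the three reaches a number, as summarised by the limit of > 60000 nM in this assay, at which 3 of the 3 values shown sit. The steps among them, a step that the two limits leave unreadable from compound 1 to compound 2, a step that the two limits leave unreadable from compound 1 to compound 3 and a step that the two limits leave unreadable from compound 2 to compound 3, cannot be read in size or direction, since both ends of each step sit at the limit.

Compound 4 `Cn1ccc2c(Oc3ccc(NC(=O)c4nn(-c5ccc(Cl)c(F)c5)ccc4=O)cc3F)ccnc21` differs from compound 3 by 4-chloro-3-fluorophenyl in place of phenyl on an aromatic nitrogen. All three measured steps change the same phenyl ring on the aromatic nitrogen, and all three are unreadable, so they give no direction for this change either; they show only that methoxy, bromo and hydrogen at that ring all leave the compounds at the limit in this assay.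

Compound 4 is therefore expected to remain near that limit as well, with an estimated step that the limit leaves unreadable from compound 3 to compound 4. The estimate for compound 4 in this assay is 80000 nM, with a range from 20000 nM to 300000 nM.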

Compound 4, half-maximal inhibitory concentration: 17900 nM
Beside the measured number, compound 4's estimate is 4.5-fold (0.65 log units) above it, outside the stated range (below it).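

In this assay, the phenyl ring on the aromatic nitrogen now proves to be a place where a change can be read in direction: 4-chloro-3-fluorophenyl in place of phenyl gives an at least 3.3-fold lower number from compound 3 to compound 4 (0.52 log units; beyond the scatter). As far as these compounds go, the same group gives an at least 3.3-fold lower number from compound 2 to compound 4 (0.52 log units; beyond the scatter) in place of 4-bromophenyl, and an at least 3.3-fold lower number from compound 1 to compound 4 (0.52 log units; beyond the scatter) in place of 4-methoxyphenyl, so it goes beyond the scatter against all three earlier groups, although the full size of each step stays unknown and the steps among compound 1, compound 2 and compound 3 still cannot be read. Compound 4 alone reaches a number, while the other compounds remain at a limit and not at a measured value: the limit of > 60000 nM in this assay, at which 3 of the 4 values shown sit.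

The compounds shown leave open whether the chloro or the fluoro group alone would bring a number within the range of the assay, or whether only the two together do so. They also leave open how far the value would move with other groups on this ring, such as an amine, a carboxylic acid or a longer chain in place of the halogens.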